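Taking the nitro group off compound 2

This account rests on a few compounds, and the source may have more. Where it says the series, first, only, none or still open, it means among the compounds named here.

In a functional assay on HeLa cells (Homo sapiens) for antiproliferative activity, read by MTT assay, with a stated time of 48 h (on this read-out higher numbers stand for weaker inhibition and lower numbers for stronger inhibition), compound 1 `O=[N+]([O-])c1ccc(-c2nn(-c3ccccc3)cc2C(Nc2nc3ccccc3s2)c2c(O)ccc3ccccc23)cc1` gives 6810 nM and compound 2 `COc1ccc2nc(NC(c3cn(-c4ccccc4)nc3-c3ccc([N+](=O)[O-])cc3)c3c(O)ccc4ccccc34)sc2c1` gives 5540 nM. Within the data shown here, these are the only two numbers so far, and they lie within the scatter of each other, so compound 2 does not stand apart from compound 1.

Compound 3 `COc1ccc2nc(NC(c3cn(-c4ccccc4)nc3-c3ccccc3)c3c(O)ccc4ccccc34)sc2c1` has hydrogen in place of nitro on an aromatic carbon, para to a large group, and is otherwise compound 2: hydrogen in place of nitro on an aromatic carbon. In other words, 4-nitrophenyl becomes phenyl.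

Among the measured compounds shown here, the only measured step, a 1.2-fold lower number from compound 1 to compound 2 (0.09 log units; within the scatter), is methoxy in place of hydrogen at a different place. For the measured compounds named here, it is therefore only indirect evidence, and no measured pair tests the loss of nitro. The data give no basis for a direction, so the working expectation in this assay is no step beyond the scatter, held with wide margins. The estimated step is a 1.1-fold higher number from compound 2 to compound 3 (0.03 log units; within the scatter). For compound 3 the expected value is 6000 nM, with an estimated range of 2200 nM to 16000 nM.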

Compound 3, half-maximal inhibitory concentration: 8290 nM
Beside the measured number, compound 3's estimate is 1.4-fold (0.14 log units) below it, within the range that was stated.
By their numbers in this assay, from the lowest: compounds 2, 1 and 3 (each within the scatter of the next).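

In this assay, among these compounds, going from 4-nitrophenyl to phenyl gives a 1.5-fold higher number from compound 2 to compound 3 (0.18 log units; within the scatter), which is the first direct reading of this position, on an aromatic carbon para to a large group. Compound 2 and compound 3 cannot be told apart in this read-out, so the nitro group, with its 3 heavy atoms and 2 hydrogen-bond acceptors, is not required for the antiproliferative activity seen at this level, and the plain phenyl serves as well within the scatter on the methoxy-bearing core. No measurement available here bears on why this exchange leaves the number inside the scatter.

The compounds shown leave open whether any group at this place can move the number beyond the scatter, for example an amine or a carboxylic acid in place of the hydrogen of compound 3. Among the compounds shown here, also open is whether hydrogen in place of nitro reads the same way on the core of compound 1, which carries hydrogen where compound 2 carries methoxy, since the only two steps in hand both lie within the scatter.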